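The source may report more compounds than this note shows. Statements on the series, on what has been measured and on what is new or still open speak of the compounds shown alone.

Values so far in a functional assay on K562 cells (Homo sapiens) for cytotoxicity, read by MTT assay, with a stated time of 72 h; on this read-out higher numbers stand for weaker inhibition and lower numbers for stronger inhibition:
- compound 1 `C=C1C(=O)[C@@]23C(=O)OC[C@]4(C(=O)CCC(C)(C)[C@H]4C=O)[C@@H]2CC[C@@H]1[C@H]3OC(C)=O` at 1390 nM
- compound 2 `C=C1C(=O)[C@@]23C(=O)OC[C@]4(C(=O)CCC(C)(C)[C@H]4C=O)[C@@H]2CC[C@@H]1[C@H]3OC(=O)c1ccc(C)cc1` at 1270 nM

Compound 2 at 1270 nM stands within the scatter of compound 1 at 1390 nM and the two cannot be separated on these numbers. The open case is compound 3 `C=C1C(=O)[C@@]23C(=O)OC[C@]4(C(=O)CCC(C)(C)[C@H]4C=O)[C@@H]2CC[C@@H]1[C@H]3OC(=O)c1ccc(OC)cc1` with methoxy in place of methyl on an aromatic carbon, para to a large group, a difference that counts out as methoxy in place of methyl on an aromatic carbon in full.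

Within the data shown here, one measured step bears on this, and only indirectly: a 1.1-fold lower number from compound 1 to compound 2 (0.04 log units; within the scatter) came from putting 4-methylphenyl in place of methyl on a carbonyl carbon. Among the measured compounds shown here, no measured compound carries methoxy, so the data hold no direct test of this change. With that one step as the guide, a smaller change within the same group is expected to give no shift beyond the scatter in this assay on either side. The expected step is a 1.0-fold higher number from compound 2 to compound 3 (0.01 log units; within the scatter) and it carries no firm direction. For compound 3 the estimated value is 1300 nM with an expected range of 700 nM to 2500 nM for now.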

Compound 3, half-maximal inhibitory concentration: 1650 nM
The estimate for compound 3 lay 1.3-fold (0.10 log units) below the measured number; the range from low to high includes it.
By their numbers in this assay, from the lowest: compounds 2, 1 and 3 (each within the scatter of the next).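

In this assay, among these compounds, methoxy in place of methyl on the aromatic carbon, para to a large group, gives a 1.3-fold higher number from compound 2 to compound 3 (0.11 log units; within the scatter), the first reading of a change on the ring itself, and this swap of the outer group stays within the scatter. Measured against the small group of compound 1, 4-methoxyphenyl in place of methyl on the carbonyl carbon gives a 1.2-fold higher number from compound 1 to compound 3 (0.07 log units; within the scatter) and is also within the scatter, so two different aromatic groups on this carbonyl carbon now sit level with methyl on these numbers. No supporting measurement is available to explain these results.

On these data alone, the three compounds hold the shared core constant and vary only methyl, 4-methylphenyl and 4-methoxyphenyl on the carbonyl carbon, so it remains open whether an amine or a carboxylic acid at the same ring position, or a longer chain in place of methyl, would move the number beyond the scatter. As far as these compounds go, it also remains open what a free hydroxyl in place of the whole ester would do in this read-out.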